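Swapping an ester for hydroxymethyl at the assay limit

A few compounds are considered here, and "the series" means these few. Any claim that something is new, unique, unknown or untested is made for them only; others in the source may bear on it.

Compound 2 `CCOC(=O)[C@@]1(C(=O)Nc2ccccc2Cl)C[C@@H]1c1cc(OC)c(OC)c(OC)c1` gives > 100000 nM in a functional assay on HeLa cells (Homo sapiens) for cytotoxicity, read by MTT assay, with a stated time of 48 h (on this read-out lower numbers stand for stronger inhibition and higher numbers for weaker inhibition), and this is a limit of the assay and not a number. Its mirror image, compound 3 `CCOC(=O)[C@]1(C(=O)Nc2ccccc2Cl)C[C@H]1c1cc(OC)c(OC)c(OC)c1`, gives a true number of 42400 nM. This is an at least 2.3-fold lower number from compound 2 to compound 3 (0.37 log units; beyond the scatter), and the only structural basis for it is the fact that compounds 2 and 3 differ only in the configuration as drawn.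

Compound 4 `COc1cc([C@H]2C[C@@]2(CO)C(=O)Nc2ccccc2Cl)cc(OC)c1OC` keeps the configuration of compound 2 but changes one group: hydroxymethyl in place of ethoxycarbonyl on a saturated ring carbon. Going by the values given here, no measured step isolates this swap, so the mirror-image step gives only a sense of how far this series has moved so far. The nearest guide is compound 1 `COc1cc([C@H]2C[C@@]2(CO)C(=O)Nc2ccccc2)cc(OC)c1OC`, which also carries hydroxymethyl on a saturated ring carbon. Compound 1 gives > 100000 nM in this assay, which is again a limit. Overall, the picture is set by the limit of > 100000 nM in this assay, at which 2 of the 3 values shown sit, and only compound 3 gives a true number.

Nothing here points to a clear gain, so no change beyond the scatter is expected, and the result may again be reported only as a limit. The estimated change is a number no higher from compound 2 to compound 4 (the limit leaves the size open). For compound 4 the estimated value is 100000 nM, with an expected range of 40000 nM to 250000 nM.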

Compound 4, half-maximal inhibitory concentration: > 100000 nM
Compound 4: no number, only a limit; the forecaster's own chance of this, stated with the estimate: 65%; the middle value sits exactly at the limit.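

In this assay compound 4 gives > 100000 nM, which is a limit of the assay and not a number. Compound 1 and compound 2 also sit at limits, and the steps from each of them to compound 4 cannot be read. The compounds shown leave open whether hydroxymethyl in place of ethoxycarbonyl, or chloro in place of hydrogen, changes the result at all.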